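A 3-Hydroxyphenyl Group in Place of Thiophen-3-yl

A few compounds are considered here, and "the series" means these few. Any claim that something is new, unique, unknown or untested is made for them only; others in the source may bear on it.

In a functional assay on A549 cells (Homo sapiens) for cytotoxicity (a higher number here means a weaker inhibitor, a lower number a stronger inhibitor), compound 3 (`C=C/C=C\[C@H](C)[C@H](OC(N)=O)[C@@H](C)[C@H](O)[C@@H](C)C/C(C)=C\[C@H](C)[C@@H](O)[C@@H](C)/C=C\CCc1ccsc1`) gives 4000 nM, the highest number of the three measured, while compound 1 (`C=C/C=C\[C@H](C)[C@H](OC(N)=O)[C@@H](C)[C@H](O)[C@@H](C)C/C(C)=C\[C@H](C)[C@@H](O)[C@@H](C)/C=C\CCc1cccc(Cl)c1`) gives 580 nM and compound 2 (`C=C/C=C\[C@H](C)[C@H](OC(N)=O)[C@@H](C)[C@H](O)[C@@H](C)C/C(C)=C\[C@H](C)[C@@H](O)[C@@H](C)/C=C\CCc1cccc(OC)c1`) gives 600 nM. Compound 4 (`C=C/C=C\[C@H](C)[C@H](OC(N)=O)[C@@H](C)[C@H](O)[C@@H](C)C/C(C)=C\[C@H](C)[C@@H](O)[C@@H](C)/C=C\CCc1cccc(O)c1`) differs from compound 3 as follows: 3-hydroxyphenyl in place of thiophen-3-yl on a saturated chain carbon, two bonds along the chain from a double-bonded chain carbon. For the measured compounds named here, two steps bear on this change, a 6.9-fold higher number from compound 1 to compound 3 (0.84 log units; beyond the scatter) and a 6.7-fold higher number from compound 2 to compound 3 (0.82 log units; beyond the scatter), and both lie beyond the scatter. The step of a 1.0-fold higher number from compound 1 to compound 2 (0.01 log units; within the scatter) lies within it. Going by the values given here, no hydroxy compound has been measured, but compound 4 regains a substituted phenyl ring, so a step of similar size in the opposite direction is expected. The expected change is a 5.0-fold lower number from compound 3 to compound 4 (0.70 log units; beyond the scatter). For compound 4 the estimate is 800 nM, within an expected range of 300 nM to 2500 nM.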

Compound 4, half-maximal inhibitory concentration: 190 nM
The estimate for compound 4 lay 4.2-fold (0.62 log units) above the measured number; the whole stated range lies above it.
By their numbers in this assay, from the lowest: compound 4; then compounds 1 and 2 (each within the scatter of the next); then compound 3.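

In this assay the 3-hydroxyphenyl group does more than restore a substituted phenyl ring, giving a 21-fold lower number from compound 3 to compound 4 (1.32 log units; beyond the scatter) and also separating from the two other substituted rings, with a 3.2-fold lower number from compound 2 to compound 4 (0.50 log units; beyond the scatter) and a 3.1-fold lower number from compound 1 to compound 4 (0.48 log units; beyond the scatter). Chloro and methoxy had given values within the scatter of each other, so the choice of ring substituent at this position only now shows an effect on the number. Nothing available explains why the hydroxy compound gives the lowest number. On these data alone, whether an amine or a carboxylic acid in place of the hydroxy group would keep this gain remains open, as does the result of a hydroxy group on the thiophen-3-yl ring.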